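Chloro removal in the amide series: compound 2 to compound 3

This account rests on a few compounds, and the source may have more. Where it says the series, first, only, none or still open, it means among the compounds named here.

Compound 1 `CCOc1ccccc1OCCSC(=S)N[C@H]1CCOC1=O` and compound 2 `O=C(CNc1ccc(Cl)cc1Cl)N[C@H]1CCOC1=O` share the same core and were run in a functional assay on DU-145 cells (Homo sapiens) for antiproliferative activity, read by MTT assay, with a stated time of 72 h; a higher number here means a weaker inhibitor, a lower number a stronger inhibitor. Compound 1 gives 28300 nM in this assay. Compound 2 reaches only a limit of the assay in this assay, > 64000 nM, so no number is known for it. Within the data shown here, on the two values shown, compound 2 therefore sits at the weak end, as described by the limit of > 64000 nM in this assay, at which 1 of the 2 values shown sits, while compound 1 is the one with a measured number.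

Compound 3 `O=C(CNc1ccc(Cl)cc1)N[C@H]1CCOC1=O` differs from compound 2 in a single place: hydrogen in place of chloro on an aromatic carbon. Among the measured compounds shown here, no pair of measured compounds differs in one place, so no measured step gives the size of this change. The expectation for the step from compound 2 to compound 3 in this assay is a change of about a step that the limit leaves unreadable from compound 2 to compound 3, which is not beyond the scatter, with a real chance that compound 3 also returns only a limit. Compound 3 is estimated at 90000 nM in this assay, expected between 40000 nM and 200000 nM.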

Compound 3, half-maximal inhibitory concentration: > 64000 nM
Compound 3 was reported as a limit; the forecaster's own chance of this, stated with the estimate: 75%; the middle value lies beyond the limit too.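

No step can be read from compound 2 to compound 3 in this assay, as both compounds return only a limit of the assay and not a number: the limit of > 64000 nM in this assay, at which 2 of the 3 values shown sit.

The compounds shown leave open whether hydrogen in place of chloro on an aromatic carbon changes antiproliferative activity in this amide series at all.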